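Ethyl for trifluoromethyl on compound 3

The source may hold more compounds than are shown below. What is called first, only, known or untested is meant among the compounds shown, and "the series" means these compounds.

Within the data shown here, in an ADME assay (liver) for metabolic stability, with Liver microsome (Canis lupus familiaris) as the target, read by LC-MS, using microsomes, with a stated time of 30 min, tested at 4 uM (a higher number here means that more of the compound is left, a lower number that less of the compound is left), compound 3 `Cc1nc(N2CCN(C)CC2)c2nc(-c3ccccc3C(F)(F)F)n(C3CCOCC3)c2n1` gives 61%, the middle of the three numbers so far: compound 1 `CCN1CCN(c2nc(C)nc3c2nc(-c2ccccc2Cl)n3CCOC)CC1` gives 86% and compound 2 `COCCn1c(-c2ccccc2Cl)nc2c(N3CCN(C(C)=O)CC3)nc(C)nc21` gives 34%. Compound 4 `CCc1ccccc1-c1nc2c(N3CCN(C)CC3)nc(C)nc2n1C1CCOCC1` differs from compound 3 in one place (ethyl in place of trifluoromethyl on an aromatic carbon). Among the measured compounds shown here, the only measured single change is a number 52 percentage points lower from compound 1 to compound 2 (beyond the scatter), with acetyl in place of ethyl on an amine nitrogen in a ring. That is a different change in a different place, so it shows only that one edit can move this assay a long way. No measurement covers the present swap, so only a moderate fall is expected, and with wide uncertainty. The expected step is a number 13 percentage points lower from compound 3 to compound 4 (beyond the scatter). The estimate for compound 4 is 48%, expected between 25% and 70%.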

Compound 4, percent of the compound remaining: 74%
The estimate for compound 4 lay 26 percentage points below the measured number; measured number above the stated range.
By their numbers in this assay, from the lowest: compound 2; then compound 3; then compound 4; then compound 1.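

In this assay, ethyl in place of trifluoromethyl gives a number 13 percentage points higher from compound 3 to compound 4 (beyond the scatter). The earlier step came from a change on a ring amine nitrogen, whereas this one shows that an edit on an aromatic carbon, ortho to a large group, can also shift the number, and that trifluoromethyl is not required there for a good share of compound to remain. No measured evidence accounts for the rise. Going by these compounds, whether a nitrile or a propyl chain at this carbon would raise the number further remains open. So does whether this swap would give a similar step with other groups elsewhere on the shared core.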